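This account rests on a few compounds, and the source may have more. Where it says the series, first, only, none or still open, it means among the compounds named here.

The study turns on two cores and a single change made on each. Compound 1, `COC(=O)c1c(-c2ccc([N+](=O)[O-])cc2)oc2ccccc2c1=O`, carries a nitro group on its pendant ring, and compound 2, `COC(=O)c1c(-c2ccc(O)cc2)oc2ccccc2c1=O`, differs from it by hydroxy in place of nitro on an aromatic carbon. In a functional assay on MCF7 cells (Homo sapiens) for cytotoxicity, read by MTT assay, with a stated time of 6 days (on this read-out higher numbers stand for an effect only at larger amounts of compound and lower numbers for an effect already at smaller amounts), compound 1 gives > 25 ug/mL, which is a limit of the assay and not a number. Compound 2 also gives only a limit, > 25 ug/mL. The step that the two limits leave unreadable from compound 1 to compound 2 therefore cannot be sized because the limit of > 25 ug/mL in this assay, at which 2 of the 3 values shown sit, covers both of its ends.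

Compound 3, `COc1ccc2oc(-c3ccc([N+](=O)[O-])cc3)c(C(=O)O)c(=O)c2c1`, rests on a core that is not the core of compound 1; the difference between the two cores is not broken down here. In this assay, going by the values given here, compound 3 gives 15.9 ug/mL, the only number among the three measured values.

Compound 4, `COc1ccc2oc(-c3ccc(O)cc3)c(C(=O)O)c(=O)c2c1`, has not been measured. It differs from compound 3 by hydroxy in place of nitro on an aromatic carbon, the same change, at the same place, as that from compound 1 to compound 2. That earlier step gave no readable size, so the pair of compound 1 and compound 2 offers no guide to direction. The expectation for compound 4 rests on compound 3 and its value of 15.9 ug/mL, with the change itself unsized. Compound 4 is expected to give about 20 ug/mL, most likely between 8 ug/mL and 50 ug/mL. This would mean an expected step of a 1.3-fold higher number from compound 3 to compound 4 (0.10 log units; within the scatter), with a real chance that only a limit is reported.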

Compound 4, concentration for half-maximal effect: > 25 ug/mL
Compound 4 gave a limit, no number; the forecaster's own chance of this, stated with the estimate: 45%; middle value at least 1.2-fold (0.09 log units) away from the limit.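

On the core of compound 3, hydroxy in place of nitro on an aromatic carbon gives an at least 1.5-fold higher number from compound 3 to compound 4 (0.19 log units; that floor lies within the scatter) in this assay; the far end of this step is a limit of the assay and not a number, so the true size of the step may be larger than its floor, but a real change is not shown. The step with the same change on the core of compound 1 cannot be read, so that core offers no size to set against the step on the core of compound 3. The compounds therefore do not show whether the change carries over from one core to the other with a similar effect, because the values that would decide this sit at a single limit: the limit of > 25 ug/mL in this assay, at which 3 of the 4 values shown sit.

As far as these compounds go, how far the number of compound 4 actually lies from that of compound 3 stays open, since only a floor is known for this step. Going by these compounds alone, also open is what an amine or a nitrile would give in the same place, para to a large group, on the core of compound 3, where nitro is the only group with a readable value.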